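Octyl hydrazone of a fluoroquinoline series: expected cytotoxicity

The compounds below may be only part of what the source reports. "The series", "measured", "known", "first", "only" and "open" are said of these compounds alone.

Compound 3 `CN(C)C(=O)C[C@H](CSc1ccccc1)Nc1c(C(=O)N/N=C/c2cc(F)ccc2O)cnc2ccc(F)cc12` has no result in an ADME assay on Vero cells (Chlorocebus sabaeus) for cytotoxicity, read by MTT assay, with a stated time of 72 h; a lower number here means a stronger inhibitor, a higher number a weaker inhibitor; for compound 3 the entry reads "not determined" (no result reported). The two values shown for its relatives sit at a limit, as the limit of > 62.5 ug/mL in this assay, at which 2 of the 3 values shown sit, states. In this assay compound 1 `CN(C)C(=O)C[C@H](CSc1ccccc1)Nc1c(C(=O)N/N=C/c2cccnc2)cnc2ccc(F)cc12` gives > 62.5 ug/mL, a limit of the assay. In this assay compound 2 `COc1ccc(/C=N/NC(=O)c2cnc3ccc(F)cc3c2N[C@@H](CSc2ccccc2)CC(=O)N(C)C)cc1O` gives > 62.5 ug/mL, also a limit. The step that the two limits leave unreadable from compound 1 to compound 2 is therefore of unreadable size. Compound 4 `CCCCCCCC/C=N/NC(=O)c1cnc2ccc(F)cc2c1N[C@@H](CSc1ccccc1)CC(=O)N(C)C` differs from compound 3 by octyl in place of 5-fluoro-2-hydroxyphenyl on a carbon with a double bond to nitrogen. Going by the values given here, no measured step bears on this change, and both measured relatives reach only the limit, so no shift beyond the scatter is expected in this assay. For compound 4 the estimate is 60 ug/mL, with a range from 25 ug/mL to 120 ug/mL.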

Compound 4, half-maximal inhibitory concentration: > 62.5 ug/mL
Compound 4 gave a limit, no number; the forecaster's own chance of this, stated with the estimate: 65%; at least 1.0-fold (0.01 log units) between middle value and limit.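

In this assay compound 4 gives > 62.5 ug/mL, a limit and not a number. Its steps from compound 1 and compound 2 therefore cannot be read. The compounds shown leave open whether compound 1, compound 2 and compound 4 differ at all in this assay.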